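This account rests on a few compounds, and the source may have more. Where it says the series, first, only, none or still open, it means among the compounds named here.

Measured so far:
Compound 1 `COc1ccc(/C=C/C(=O)c2cc(OC)c(OC)c(OC)c2)cc1OCCCC(=O)NCCCNCCCCNCCN`: > 100000 nM, a limit of the assay and not a number
Compound 2 `COc1ccc(/C=C/C(=O)c2cc(OC)c(OC)c(OC)c2)cc1OCCCC(=O)NCCCCN(CCCN)CCCCNCCCN`: 89100 nM

Among the compounds with values here, in a functional assay on HT-29 cells (Homo sapiens) for antiproliferative activity, read by MTT assay, with a stated time of 48 h (a lower number here means a stronger inhibitor, a higher number a weaker inhibitor), compound 2 gives 89100 nM, the only actual number so far. Compound 3 `COc1ccc(/C=C/C(=O)c2cc(OC)c(OC)c(OC)c2)cc1OCCCC(=O)NCCCCNCCCN` has hydrogen in place of 4-((3-aminopropyl)amino)butyl on an amine nitrogen of compound 2: hydrogen in place of 4-((3-aminopropyl)amino)butyl on an amine nitrogen. Within the data shown here, no measured pair shows what such a change does in this assay, so the only anchor is compound 2 at 89100 nM, and no shift beyond the scatter is expected. The expected size of the step is a 1.3-fold lower number from compound 2 to compound 3 (0.10 log units; within the scatter). Compound 3 is estimated at 70000 nM, with an expected range of 25000 nM to 160000 nM.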

Compound 3, half-maximal inhibitory concentration: > 100000 nM
Compound 3: only a limit was reported; the forecaster's own chance of this, stated with the estimate: 35%; middle value at least 1.4-fold (0.15 log units) away from the limit.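

Within the data shown here, replacing 4-((3-aminopropyl)amino)butyl with hydrogen on this amine nitrogen gives the first step at this position in this assay: an at least 1.1-fold higher number from compound 2 to compound 3 (0.05 log units; that floor lies within the scatter). That figure is only a floor, so the real change could be small or large, and the step from compound 1 to compound 3 cannot be read at all. Most of these compounds therefore offer no exact number to compare: the limit of > 100000 nM in this assay, at which 2 of the 3 values shown sit.

On these data alone, it remains open whether a benzyl group or a longer chain on this amine nitrogen would shift the number. The same question applies to a carboxylic acid at the chain end.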